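This account rests on a few compounds, and the source may have more. Where it says the series, first, only, none or still open, it means among the compounds named here.

Measured compounds:
compound 1, `NC(=O)c1cccc(CCCN(CCC[C@H](N)C(=O)O)C[C@H]2O[C@@H](n3cnc4c(N)ncnc43)[C@H](O)[C@@H]2O)c1`, 3000 nM
compound 2, `NC(=O)c1cccc(CCCCN(CC[C@H](N)C(=O)O)C[C@H]2O[C@@H](n3cnc4c(N)ncnc43)[C@H](O)[C@@H]2O)c1`, 840 nM

In an assay on cells for inhibition of Nicotinamide N-methyltransferase (Homo sapiens), read by fluorescence and coupled enzyme assay, with a stated time of 10 min, in the presence of a further agent that is not named here (on this read-out higher numbers stand for weaker inhibition and lower numbers for stronger inhibition), compound 2 gives the lowest of the two numbers; compound 1 gives a higher one, and that gap lies beyond the scatter. Compound 3, `NC(=O)c1cccc(CCCCN(CCC[C@H](N)C(=O)O)C[C@H]2O[C@@H](n3cnc4c(N)ncnc43)[C@H](O)[C@@H]2O)c1`, is not yet measured. It differs from compound 2 by 2-amino-2-carboxyethyl in place of amino(carboxy)methyl on a saturated chain carbon, two bonds along the chain from an amine nitrogen. Within the data shown here, no single-change pair covers this chain extension, so its direction is open; a modest weakening is expected, with the step from compound 2 to compound 3 estimated as a 1.8-fold higher number from compound 2 to compound 3 (0.25 log units; within the scatter). Compound 3 is expected to give 1500 nM, within 500 nM to 5000 nM.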

Compound 3, inhibition constant: 540 nM
Compound 3: middle estimate off by 2.8-fold (0.44 log units), on the high side; the measured number falls inside the stated range.
By their numbers in this assay, from the lowest: compounds 3 and 2 (each within the scatter of the next); then compound 1.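

In this assay, 2-amino-2-carboxyethyl in place of amino(carboxy)methyl on a saturated chain carbon, two bonds along the chain from an amine nitrogen, gives a step that does not separate the two compounds (a 1.6-fold lower number from compound 2 to compound 3 (0.19 log units; within the scatter)). By contrast, 3-carbamoylbenzyl in place of 3-carbamoylphenyl, three bonds along the chain from an amine nitrogen, gives a step that clears the scatter (a 5.6-fold lower number from compound 1 to compound 3 (0.74 log units; beyond the scatter)). Nothing available explains either step. Still open, as far as these compounds go, is whether a longer chain on either arm keeps this level, and whether a nitrile or a carboxylic acid can replace the carbamoyl group.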